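The source may hold more compounds than are shown below. What is called first, only, known or untested is meant among the compounds shown, and "the series" means these compounds.

Compound 1 `COc1ccc(SCc2ccc(/C=C/C(=O)Nc3ccccc3N)cc2)cc1OC` gives 65.5%
Compound 2 `Cc1cc(C)cc(SCc2ccc(/C=C/C(=O)Nc3ccccc3N)cc2)c1` gives 46.1%

In a functional assay on A549 cells (Homo sapiens) for inhibition, read by CCK-8 assay, with a stated time of 72 h, tested at 2 uM (on this read-out lower numbers stand for less inhibition of growth and higher numbers for more inhibition of growth at the one concentration tested), compound 2 stands lower of the two, and compound 1 lies above it by more than the scatter. The next compound is compound 3 `Nc1ccccc1NC(=O)/C=C/c1ccc(CSc2ccc(Cl)cc2)cc1`, which keeps the shared core and differs from compound 2 only in the group on the sulfur (4-chlorophenyl in place of 3,5-dimethylphenyl on a sulfur). Here 4-chlorophenyl takes the place of 3,5-dimethylphenyl on a sulfur whose other neighbour is a saturated chain carbon.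

Among the compounds with values here, only one measured step bears on this change, and it sits at the same place, where 3,5-dimethylphenyl replaced 3,4-dimethoxyphenyl (a number 19.4 percentage points lower from compound 1 to compound 2 (beyond the scatter)). It shows that a change on this sulfur can move the read-out by a modest amount. Within the data shown here, it does not show the direction for a chlorine-bearing group, since no measured compound carries one. A step no larger than that one is therefore expected, leaning slightly upward and possibly not beyond the scatter. The expected size of the change is small (a number 5.9 percentage points higher from compound 2 to compound 3 (within the scatter)). For compound 3 the estimated value is 52% with an expected range (35% to 70%).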

Compound 3, percent growth inhibition at one concentration: 55.3%
Compound 3: middle estimate off by 3.3 percentage points, on the low side; measured number inside the range.
By their numbers in this assay, from the lowest: compounds 2 and 3 (each within the scatter of the next); then compound 1.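

In this assay the exchange of 3,5-dimethylphenyl for 4-chlorophenyl on the sulfur comes to a number 9.2 percentage points higher from compound 2 to compound 3 (within the scatter), so at this place a group carrying two methyl groups and one carrying a chlorine cannot be told apart. Measured against the 3,4-dimethoxyphenyl group, the same 4-chlorophenyl group gives a number 10.2 percentage points lower from compound 1 to compound 3 (beyond the scatter), which shows that the gap seen earlier is not peculiar to the 3,5-dimethylphenyl group and leaves compound 1 as the only one of the three standing clear of the other two. Nothing at hand explains why the three groups fall this way.

The compounds shown leave open whether both methoxy groups of compound 1 are needed, since a 4-methoxyphenyl group, or a phenyl group with no substituent, would separate the contribution of each from that of the ring alone. They also leave open what an amine or a carboxylic acid on this ring would do, and whether a longer chain in place of the single saturated chain carbon on the sulfur would keep the read-out where it stands.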